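The source may hold more compounds than are shown below. What is called first, only, known or untested is meant among the compounds shown, and "the series" means these compounds.

Compound 1, `CCCC(/N=C(\S)NCc1ccc(C(C)(C)C)cc1)c1ccc(NS(C)(=O)=O)cc1`, was examined in a functional assay with Rattus norvegicus as the target; on this read-out lower numbers stand for an effect already at smaller amounts and higher numbers for an effect only at larger amounts of compound. In this assay compound 1 reaches only the limit of the assay, > 100000 nM, and no number. Compound 2, `Cc1ccc(C(C)/N=C(\S)NCc2ccc(C(C)(C)C)cc2)cc1`, likewise gives in this assay only the limit > 100000 nM. Compound 3, `C[C@@H](/N=C(\S)NCc1ccc(C(C)(C)C)cc1)c1ccccc1`, also stops in this assay at the limit > 100000 nM. Compound 1 thus stands where every measured compound stands: at the limit of > 100000 nM in this assay, at which 3 of the 3 values shown sit. Among the compounds with values here, no step between measured compounds is known; none of them yields a number, so nothing can be sized or ordered among them.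

Compound 4, `CCC(/N=C(\S)NCc1ccc(C(C)(C)C)cc1)c1ccc(NS(C)(=O)=O)cc1`, differs from compound 1 in one place: hydrogen in place of methyl on a saturated chain carbon, three bonds along the chain from an aromatic carbon and a double-bonded nitrogen. The change removes one saturated chain carbon and nothing else. Within the data shown here, with only limits among the measured compounds, no measured step in this assay can guide the size of the change; the expectation is that the step that the limit leaves unreadable from compound 1 to compound 4 is none beyond the scatter, with compound 4 remaining at the limit. Compound 4 is therefore estimated at 150000 nM, within a range from 50000 nM to 500000 nM, most probably reported again only as a limit.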

Compound 4, half-maximal effective concentration: > 100000 nM
Compound 4: no number, only a limit; the forecaster's own chance of this, stated with the estimate: 85%; the middle value lies beyond the limit too.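

No step can be read from compound 1 to compound 4, since both stop at a limit and give no number: the limit of > 100000 nM in this assay, at which 4 of the 4 values shown sit. In this assay the compounds shown leave open whether any change to the shared core yields a number, and what size the methyl-to-hydrogen change has.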